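Cytotoxicity notes: methyl in place of a pyridyl arm

The source may hold more compounds than are shown below. What is called first, only, known or untested is meant among the compounds shown, and "the series" means these compounds.

Compound 1 `Cc1ccc(-c2ccc3[nH]c(=O)nc(-c4ccccc4)c3c2)cn1` is known in an ADME assay on L6 cells (Rattus norvegicus) for cytotoxicity, read by fluorescence and resazurin assay, with a stated time of 72 h (on this read-out higher numbers stand for an effect only at larger amounts of compound and lower numbers for an effect already at smaller amounts), only as a limit, > 50000 nM, and sits at the limit of > 50000 nM in this assay, at which 1 of the 2 values shown sits; no number fixes its position. Compound 2 `O=c1nc(-c2ccccc2)c2ccc(-c3cccnc3)cc2[nH]1` gives a number in this assay, 7730 nM. Compound 3 `Cc1ccc2[nH]c(=O)nc(-c3ccccc3)c2c1` has not yet been measured in this assay. It differs from compound 1 by methyl in place of 6-methylpyridin-3-yl on an aromatic carbon. For the measured compounds named here, no measured step covers this change, so the expected step of a number no higher from compound 1 to compound 3 (the limit leaves the size open) is taken as lying within the scatter, leaving compound 3 near or beyond the limit. Compound 3 is thus expected at 50000 nM, in the range 15000 nM to 150000 nM.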

Compound 3, half-maximal effective concentration: > 50000 nM
Compound 3 was reported as a limit; the forecaster's own chance of this, stated with the estimate: 60%; the middle value lies on the limit itself.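

Compound 1 stands only as a limit in this assay, > 50000 nM. For the compounds shown here, compound 3 is likewise a limit, > 50000 nM, so no step between compound 1 and compound 3 can be read. On these data alone, whether methyl in place of 6-methylpyridin-3-yl shifts the read-out at all stays open.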